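Aryl sulfonyl variation in the indolylamino series

The compounds below may be only part of what the source reports. "The series", "measured", "known", "first", "only" and "open" are said of these compounds alone.

Compound 1 `Cc1ccc(S(=O)(=O)c2cc3cnc(Nc4ccc5[nH]ccc5c4)nc3n(C)c2=O)cc1` gives 750 nM in a functional assay on K562 cells (Homo sapiens) for inhibition, read by trypan blue exclusion, with a stated time of 72 h; on this read-out lower numbers stand for stronger inhibition and higher numbers for weaker inhibition. Compound 2 `Cc1ccc(S(=O)(=O)c2cc3cnc(Nc4ccc5cc[nH]c5c4)nc3n(C)c2=O)cc1` gives 15000 nM in this assay, the change being a 20-fold higher number from compound 1 to compound 2 (1.30 log units; beyond the scatter). Compound 3 `COc1ccc(S(=O)(=O)c2cc3cnc(Nc4cccc5[nH]ccc45)nc3n(C)c2=O)cc1` gives 5000 nM in this assay and stands second highest of the three numbers, nearest to compound 2 and furthest from compound 1, both gaps beyond the scatter. Compound 4 `Cc1ccc(S(=O)(=O)c2cc3cnc(Nc4cccc5[nH]ccc45)nc3n(C)c2=O)cc1` is not yet measured. It differs from compound 3 by methyl in place of methoxy on an aromatic carbon; seen one bond further out, (4-methoxyphenyl)sulfonyl becomes (4-methylphenyl)sulfonyl. For the measured compounds named here, the only measured step, a 20-fold higher number from compound 1 to compound 2 (1.30 log units; beyond the scatter), concerns the indolyl attachment and not this part of the molecule, so no measured step bears on the present change. The expected step in this assay is therefore none beyond the scatter, no change at the digits printed from compound 3 to compound 4 (within the scatter). Compound 4 is estimated at 5000 nM, with a range from 2000 nM to 12000 nM.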

Compound 4, half-maximal inhibitory concentration: 5000 nM
For compound 4 middle estimate and measured number coincide at the digits printed; measured number inside the range.
By their numbers in this assay, from the lowest: compound 1; then compounds 3 and 4 (each within the scatter of the next); then compound 2.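

In this assay, the exchange of (4-methoxyphenyl)sulfonyl for (4-methylphenyl)sulfonyl gives no change at the digits printed from compound 3 to compound 4 (within the scatter), so methoxy and methyl read alike at this place when the attachment is 1H-indol-4-yl. With (4-methylphenyl)sulfonyl held constant, 1H-indol-4-yl in place of 1H-indol-6-yl gives a 3.0-fold lower number from compound 2 to compound 4 (0.48 log units; beyond the scatter), while 1H-indol-4-yl in place of 1H-indol-5-yl gives a 6.7-fold higher number from compound 1 to compound 4 (0.82 log units; beyond the scatter). Nothing at hand explains these steps.

Open, as far as these compounds go, is how an amine, a carboxylic acid or a longer chain at this place would compare with methoxy and methyl. Also open, from the compounds shown here alone, is whether the methoxy-methyl match holds with 1H-indol-5-yl or 1H-indol-6-yl.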